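Lengthening One Chain of Compound 1

The source may hold more compounds than are shown below. What is called first, only, known or untested is meant among the compounds shown, and "the series" means these compounds.

Among the compounds with values here, in a functional assay on FM3A cells (Mus musculus) for cytotoxicity (a lower number here means that less compound is needed, a higher number that more compound is needed for the effect), compound 1 `COOC1(OOC)CCCCCCCCCCC1` gives 1500 nM, the lower of the two numbers so far. Compound 2 `CCCOOC1(OOCCC)CCCCCCCCCCC1`, with propyl chains, gives 12000 nM, higher by more than the usual scatter. Compound 3 `CCCCOOC1(OOC)CCCCCCCCCCC1` is still unmeasured. It differs from compound 1 by propyl in place of hydrogen on a saturated chain carbon bound to an oxygen on an unsaturated carbon: propyl replaces a hydrogen on a saturated chain carbon, so one methyl becomes butyl. Within the data shown here, with only two numbers to go on, a rise in this assay is expected for compound 3, beyond the scatter. The expected step is a 2.7-fold higher number from compound 1 to compound 3 (0.43 log units; beyond the scatter). Compound 3 is estimated at 4000 nM, within a range of 1300 nM to 12000 nM.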

Compound 3, half-maximal effective concentration: 20000 nM
The estimate for compound 3 lay 5.0-fold (0.70 log units) below the measured number; measured number outside the range, above it.
By their numbers in this assay, from the lowest: compound 1; then compounds 2 and 3 (each within the scatter of the next).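

Putting propyl in place of hydrogen on a saturated chain carbon bound to an oxygen on an unsaturated carbon gives a 13-fold higher number from compound 1 to compound 3 (1.12 log units; beyond the scatter) in this assay and so counts as a large change. Altering this one chain, with the other methyl kept, is therefore enough to require much more compound, whereas the earlier comparison had both chains different at once. Nothing available explains this rise.

As far as these compounds go, whether a longer chain such as hexyl would raise the number further remains open. So does the effect of an amine in place of butyl.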